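A few compounds are considered here, and "the series" means these few. Any claim that something is new, unique, unknown or untested is made for them only; others in the source may bear on it.

In an ADME assay for metabolic stability, read by HPLC, in simulated gastric fluid, with a stated time of 12 h, at pH 1.2 (a lower number here means that the compound disappears faster, a higher number that the compound lasts longer), compound 3 `O=C(N[C@H](CO)C(=O)O)[C@@H]1C[C@@H](O)CN1` gives > 12 h, which is a limit and not a number. Compound 1 `O=C(O)[C@H](CO)NC(=O)[C@H]1C[C@H](O)CN1` gives > 12 h, also a limit. Compound 2 `O=C(O)[C@@H](CO)NC(=O)[C@H]1C[C@@H](O)CN1` gives > 12 h, again a limit. The position of compound 3 is therefore defined only by the limit of > 12 h in this assay, at which 3 of the 3 values shown sit.

Compound 4 `O=C(O)[C@H](CO)NC(=O)[C@@H]1C[C@@H](O)CN1` is reached by one change: the two compounds have the same atoms and bonds and differ only in configuration as drawn: 1 of 3 stereo elements differ; a stereocentre at a saturated chain carbon is drawn R in compound 3 and S in compound 4. Nothing leaves and nothing enters.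

Three measured changes of configuration bear on this. Within the data shown here, the first is a step that the two limits leave unreadable from compound 1 to compound 2, where a saturated chain carbon and a saturated ring carbon both differ. The second is a step that the two limits leave unreadable from compound 2 to compound 3, where a single saturated ring carbon differs. The third is a step that the two limits leave unreadable from compound 1 to compound 3, where all stereocentres are inverted. None of these steps has a readable size, so they offer no direction, and no step beyond the scatter is expected in this assay.

The expected change is a step that the limit leaves unreadable from compound 3 to compound 4. Compound 4 is estimated at 15 h, with an expected range of 12 h to 30 h.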

Compound 4, half-life in the ADME assay: > 12 h
Compound 4: no number, only a limit; the forecaster's own chance of this, stated with the estimate: 90%; the middle value is on the limit's open side.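

In the ADME assay compound 4 gives > 12 h, which is a limit and not a number. In a physicochemical assay for metabolic stability, read by HPLC, in phosphate buffer, with a stated time of 12 h, at pH 7.2 (on this read-out higher numbers stand for a longer-lived compound and lower numbers for a shorter-lived compound), compound 3 gives > 12 h and this is a limit. In the physicochemical assay compound 4 gives > 12 h and this is also a limit. Among these compounds, no step between compound 4 and compound 1, compound 2 or compound 3 can be read there, nor between compound 3 and compound 4 in the physicochemical assay. The compounds shown leave open whether a change of configuration shifts the half-life at all.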